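A few compounds are considered here, and "the series" means these few. Any claim that something is new, unique, unknown or untested is made for them only; others in the source may bear on it.

Three compounds share one core and differ only in the group carried on an aromatic carbon of the outer ring. In a functional assay on A-431 cells (Homo sapiens) for inhibition, read by MTT assay, with a stated time of 72 h (on this read-out higher numbers stand for weaker inhibition and lower numbers for stronger inhibition), compound 1 `O=[N+]([O-])c1ccc(-c2nnc(SCCCN3CCN(c4nc5ccccc5o4)CC3)o2)cc1` gives 46900 nM, compound 2 `Cc1ccc(-c2nnc(SCCCN3CCN(c4nc5ccccc5o4)CC3)o2)cc1` gives 100000 nM, and compound 3 `Clc1ccc(-c2nnc(SCCCN3CCN(c4nc5ccccc5o4)CC3)o2)cc1` gives 89600 nM. Compound 2 stands highest of the three numbers. Methyl in place of nitro reads a 2.1-fold higher number from compound 1 to compound 2 (0.33 log units; beyond the scatter), chloro in place of nitro reads a 1.9-fold higher number from compound 1 to compound 3 (0.28 log units; within the scatter), and chloro in place of methyl reads a 1.1-fold lower number from compound 2 to compound 3 (0.05 log units; within the scatter), so the whole set sits in a narrow band. Compound 4 `Oc1ccc(-c2nnc(SCCCN3CCN(c4nc5ccccc5o4)CC3)o2)cc1` differs from compound 2 by hydroxy in place of methyl on an aromatic carbon. For the measured compounds named here, no measured step introduces a hydroxy; the three swaps at this carbon bear only indirectly, and none of them moved the number far. The step from compound 2 to compound 4 in this assay is therefore expected to be small or none beyond the scatter, estimated at a 1.4-fold lower number from compound 2 to compound 4 (0.15 log units; within the scatter). Compound 4 is expected to give about 70000 nM in this assay, within a range from 25000 nM to 200000 nM.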

Compound 4, half-maximal inhibitory concentration: 117000 nM
Compound 4: the middle estimate sits 1.7-fold (0.22 log units) below what was measured; measured number inside the range.
By their numbers in this assay, from the lowest: compounds 1, 3, 2 and 4 (each within the scatter of the next, the first and the last beyond it).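

Hydroxy is the first group at this carbon to bring a hydrogen-bond donor, yet in this assay it does not separate from methyl (a 1.2-fold higher number from compound 2 to compound 4 (0.07 log units; within the scatter)) or from chloro (a 1.3-fold higher number from compound 3 to compound 4 (0.12 log units; within the scatter)). Among the four groups, the only steps beyond the scatter start from nitro, and the step to hydroxy is modest (a 2.5-fold higher number from compound 1 to compound 4 (0.40 log units; beyond the scatter)), while chloro, also compared with nitro, stays within the scatter of compound 1. No supporting measurement bears on why these numbers fall as they do.

From the compounds shown here alone, whether an amine, a carboxylic acid or a methoxy at this carbon would stand apart from methyl, chloro and hydroxy remains open. The same holds for a longer chain in place of the hydroxy of compound 4.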